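This account rests on a few compounds, and the source may have more. Where it says the series, first, only, none or still open, it means among the compounds named here.

Four compounds built on one shared core are compared here. Compound 1 `CCOC(=O)c1cc(-c2cc(OC)c(OC)c(OC)c2)c(-c2ccc(OC)c(OCc3ccccc3)c2)s1` carries a benzyl group on an oxygen on an aromatic ring and an ethyl ester; compound 2 `CCOC(=O)c1cc(-c2cc(OC)c(OC)c(OC)c2)c(-c2ccc(OC)c(O)c2)s1` keeps the ester but has a hydroxy group in place of the benzyloxy group; compound 3 `COc1ccc(-c2sc(C(=O)O)cc2-c2cc(OC)c(OC)c(OC)c2)cc1OCc1ccccc1` keeps the benzyloxy group but carries a carboxylic acid; compound 4 `COc1ccc(-c2sc(C(=O)O)cc2-c2cc(OC)c(OC)c(OC)c2)cc1O` joins the hydroxy group with the acid and has not yet been tested.

In a functional assay on KB cells (Homo sapiens) for antiproliferative activity, read by MTT assay, with a stated time of 72 h (on this read-out lower numbers stand for stronger inhibition and higher numbers for weaker inhibition), compound 1 reaches only the limit of the assay, > 100000 nM. Compound 2 gives 1250 nM in this assay. The change between them is hydrogen in place of benzyl on an oxygen on an aromatic ring, and it brought an at least 80-fold lower number from compound 1 to compound 2 (1.90 log units; beyond the scatter). Compound 3 also sits at the limit of this assay, > 100000 nM. The two cores, those of compound 1 and compound 3, differ by hydrogen in place of ethyl on an oxygen next to a carbonyl group, and between them lies a step that the two limits leave unreadable from compound 1 to compound 3, since both values are limits (the limit of > 100000 nM in this assay, at which 2 of the 3 values shown sit).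

Among the measured compounds shown here, from compound 3 to compound 4 the change is hydrogen in place of benzyl on an oxygen on an aromatic ring, the same change as the one from compound 1 to compound 2, at the same place. He expects the step from compound 3 to compound 4 to be an at least 5.0-fold lower number from compound 3 to compound 4 (0.69 log units; beyond the scatter), resting on the step of an at least 80-fold lower number from compound 1 to compound 2 (1.90 log units; beyond the scatter) seen on the ester core, while noting that the start point of compound 3 is itself only a limit. His estimate for compound 4 in this assay is 20000 nM, between 1500 nM and 100000 nM.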

Compound 4, half-maximal inhibitory concentration: 11200 nM
Compound 4: the middle estimate sits 1.8-fold (0.25 log units) above what was measured, and the stated range covers the measured number.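

Replacing benzyloxy by hydroxy lowers the number in this assay on both cores, so the direction of this change carries over from the ethyl ester to the carboxylic acid, where it gives an at least 8.9-fold lower number from compound 3 to compound 4 (0.95 log units; beyond the scatter). Set side by side, the two steps read as follows: the same change on two cores in this assay, an at least 80-fold lower number (1.90 log units; beyond the scatter) from compound 1 to compound 2 and an at least 8.9-fold lower number (0.95 log units; beyond the scatter) from compound 3 to compound 4; the limit leaves it open whether they differ. The size of the change on one core cannot be taken as its size on the other, since compound 1 and compound 3 both rest on a limit and each step therefore gives only a lower bound on its size: the limit of > 100000 nM in this assay, at which 2 of the 4 values shown sit.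

On these data alone, the change from ethyl ester to carboxylic acid can be read only with the hydroxy group in place, where it gives a 9.0-fold higher number from compound 2 to compound 4 (0.95 log units; beyond the scatter), and the step between the two benzyloxy compounds cannot be read, so it stays open whether that change behaves alike with benzyloxy present. Also open, as far as these compounds go, is how a methyl group or a longer chain on that oxygen, or an amide in place of the ester or acid, would read on the shared core.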